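Extending the ring methyl to ethyl: exposure notes

The source may report more compounds than this note shows. Statements on the series, on what has been measured and on what is new or still open speak of the compounds shown alone.

Measured compounds in an ADME assay on the whole organism (plasma) for pharmacokinetics, with Rattus norvegicus as the target, at a dose of 10 mg/kg by the oral route; a higher number here means more compound in the circulation at the dose given, a lower number less compound in the circulation:
compound 1, `Cc1ccc2c(c1)c(-c1ccc[nH]c1=O)c(C(=O)O)n2Cc1cc([N+](=O)[O-])ccc1F`, 59 ng.h/mL
compound 2, `O=C(NS(=O)(=O)C1CC1)c1c(-c2ccc[nH]c2=O)c2cc(Cl)ccc2n1Cc1cc([N+](=O)[O-])ccc1F`, 163 ng.h/mL
compound 3, `Cc1ccc2c(c1)c(-c1ccc[nH]c1=O)c(C(=O)NS(=O)(=O)C1CC1)n2Cc1cc([N+](=O)[O-])ccc1F`, 5.25 ng.h/mL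

Compound 3 stands lowest of the three in this assay. Both measured steps into it were large: an 11-fold lower number from compound 1 to compound 3 (1.05 log units; beyond the scatter) and a 31-fold lower number from compound 2 to compound 3 (1.49 log units; beyond the scatter). Compound 4, `CCc1ccc2c(c1)c(-c1ccc[nH]c1=O)c(C(=O)NS(=O)(=O)C1CC1)n2Cc1cc([N+](=O)[O-])ccc1F`, differs from compound 3 by methyl in place of hydrogen on a saturated chain carbon bound to an aromatic carbon. Among the measured compounds shown here, no measured step touches the same kind of change; the nearest, which altered the group on that aromatic carbon, was a 31-fold lower number from compound 2 to compound 3 (1.49 log units; beyond the scatter), but a chloro-to-methyl swap does not read across to a methyl-to-ethyl extension. For the measured compounds named here, with no direct precedent, the expectation for compound 4 is a step near the scatter, a 1.1-fold lower number from compound 3 to compound 4 (0.02 log units; within the scatter), possibly a small fall. Compound 4 is therefore estimated at 5 ng.h/mL in this assay, within 1.5 ng.h/mL to 20 ng.h/mL.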

Compound 4, area under the concentration-time curve: 91.6 ng.h/mL
Compound 4: the middle estimate sits 18-fold (1.26 log units) below what was measured, and the stated range ends below it.
By their numbers in this assay, from the lowest: compound 3; then compounds 1, 4 and 2 (each within the scatter of the next, the first and the last beyond it).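

In this assay this place proves highly sensitive to one added methyl (a 17-fold higher number from compound 3 to compound 4 (1.24 log units; beyond the scatter)), so methyl to ethyl is no minor extension in this series. Ethyl and chloro on the aromatic carbon cannot be told apart here (a 1.8-fold lower number from compound 2 to compound 4 (0.25 log units; within the scatter)), which leaves methyl as the low point among these three groups on the (cyclopropylsulfonyl)amino core. No measurement shown here accounts for the step. As far as these compounds go, whether propyl or a longer chain holds the level seen with ethyl remains open, as does the outcome with methoxy or an amine at this place.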